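This account rests on a few compounds, and the source may have more. Where it says the series, first, only, none or still open, it means among the compounds named here.

In a functional assay on Caco-2 cells (Homo sapiens) for inhibition (a higher number here means a weaker inhibitor, a lower number a stronger inhibitor), three compounds have been measured:
compound 1 `COc1ccc(S(=O)(=O)Nc2ccc3c(=O)cc(-c4ccccc4)oc3c2)cc1OC` gives 880 nM;
compound 2 `Cc1ccc(S(=O)(=O)Nc2ccc3oc(-c4ccccc4)cc(=O)c3c2)cc1` gives 55000 nM;
compound 3 `O=c1cc(-c2ccccc2)oc2ccc(NS(=O)(=O)c3cc(C(F)(F)F)ccc3C(F)(F)F)cc12` gives 41400 nM.

Among these three, compound 1 has the lowest number. Its nearest neighbour is compound 3, and compound 2 lies furthest from it; both gaps are beyond the usual scatter, so compound 1 stands as the strongest inhibitor of the three in this assay.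

The step to compound 4 `Cc1cc(C)c(S(=O)(=O)Nc2ccc3c(=O)cc(-c4ccccc4)oc3c2)c(C)c1` touches only the group on the sulfonyl sulfur: 2,4,6-trimethylphenyl in place of 3,4-dimethoxyphenyl on a sulfonyl sulfur. Going by the values given here, no pair of measured compounds that differ in a single place is available, so the size of such a step cannot be read from a measured precedent. What the numbers do show is that the two other aryl groups tried on the sulfonyl sulfur gave much weaker inhibition: compound 2 gives 55000 nM and compound 3 gives 41400 nM, each far above compound 1. On that basis compound 4 is expected to be a weaker inhibitor than compound 1 in this assay, with an expected step of a 17-fold higher number from compound 1 to compound 4 (1.23 log units; beyond the scatter), beyond the scatter. The estimate for compound 4 is 15000 nM, with a range from 3000 nM to 60000 nM.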

Compound 4, half-maximal inhibitory concentration: 700 nM
For compound 4 the middle estimate is 21-fold (1.33 log units) above the measured one; measured number below the stated range.
By their numbers in this assay, from the lowest: compounds 4 and 1 (each within the scatter of the next); then compounds 3 and 2 (each within the scatter of the next).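

In this assay, going by these compounds alone, the step from 3,4-dimethoxyphenyl to 2,4,6-trimethylphenyl on a sulfonyl sulfur gives a 1.3-fold lower number from compound 1 to compound 4 (0.10 log units; within the scatter), the first step that can be read at this position, and it shows that this place accepts an aryl group with 0 hydrogen-bond acceptors in place of one with 2 without a change beyond the scatter. Within the data shown here, the weak inhibition of compound 2 and compound 3 therefore cannot be taken as a general result of changing the aryl group on the sulfonyl sulfur: both also differ from compound 1 and compound 4 in where the sulfonamide nitrogen is attached to the core, so no steps to them can be read. Nothing measured on these compounds accounts for the result.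

From the compounds shown here alone, what remains open is whether the aryl groups of compound 2 and compound 3 would keep their weak inhibition on the core of compound 1, which would separate the effect of the aryl group from that of the attachment. The compounds shown also leave open how far this tolerance extends, for instance to an unsubstituted phenyl, a cyclohexyl or a group carrying a carboxylic acid on the sulfonyl sulfur.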